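Changing the aryl on the amine nitrogen of the core

This account rests on a few compounds, and the source may have more. Where it says the series, first, only, none or still open, it means among the compounds named here.

Of the compounds shown here, three of a shared core have been tested in a functional assay on B16-F10 cells (Mus musculus) for inhibition, read by MTT assay, with a stated time of 72 h; on this read-out higher numbers stand for weaker inhibition and lower numbers for stronger inhibition. Compound 1 `Cc1ccc(Cn2cc(CSc3nc(Nc4ccccc4C)c(C#N)c(-c4ccccc4)n3)nn2)cc1` gives > 64000 nM, which is a limit of the assay rather than a number. Compound 3 `Cc1ccc(Cn2cc(CSc3nc(Nc4ccccc4F)c(C#N)c(-c4ccccc4)n3)nn2)cc1` gives 16000 nM in this assay and stands highest among the two numbers shown. Compound 2 `Cc1ccc(Nc2nc(SCc3cn(Cc4ccc(F)cc4)nn3)nc(-c3ccccc3)c2C#N)cc1` gives 3040 nM in this assay. Within the data shown here, the only single-point step measured, an at least 4.0-fold lower number from compound 1 to compound 3 (0.60 log units; beyond the scatter), shows that swapping one small group on the aryl that sits on the nitrogen moves the read-out clearly.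

Compound 4 `Cc1ccc(Cn2cc(CSc3nc(Nc4ccc(C)cc4)c(C#N)c(-c4ccccc4)n3)nn2)cc1` differs from compound 3 by 4-methylphenyl in place of 2-fluorophenyl on a nitrogen on an aromatic ring. Among the measured compounds shown here, no measured step matches this exact change, but compound 2 also carries a 4-methylphenyl on that nitrogen and differs from compound 4 only in the substituent on the benzyl group, so its number is the closest guide. Compound 4 is therefore expected to give 4000 nM in this assay, between 1500 nM and 12000 nM, an expected step of a 4.0-fold lower number from compound 3 to compound 4 (0.60 log units; beyond the scatter).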

Compound 4, half-maximal inhibitory concentration: 8160 nM
For compound 4 the middle estimate is 2.0-fold (0.31 log units) below the measured one; the range from low to high includes it.
By their numbers in this assay, from the lowest: compound 2; then compounds 4 and 3 (each within the scatter of the next). At a limit, above all of these: compound 1.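

In this assay, the step of a 2.0-fold lower number from compound 3 to compound 4 (0.29 log units; within the scatter) means that 2-fluorophenyl and 4-methylphenyl on this nitrogen cannot be told apart. The methyl group's place on the aryl does matter, since moving from 2-methylphenyl to 4-methylphenyl gives an at least 7.8-fold lower number from compound 1 to compound 4 (0.89 log units; beyond the scatter), a step that rests on a limit and so has only a lower bound. The other end of the molecule also counts, with a 2.7-fold higher number from compound 2 to compound 4 (0.43 log units; beyond the scatter) for methyl in place of fluoro on an aromatic carbon of the benzyl group, and fluoro in place of methyl goes with a lower number at both places tested: the same change on two cores in this assay, an at least 4.0-fold lower number (0.60 log units; beyond the scatter) from compound 1 to compound 3 and a 2.7-fold lower number (0.43 log units; beyond the scatter) from compound 4 to compound 2; the limit leaves it open whether they differ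

From the compounds shown here alone, what an amine or a carboxylic acid on the aryl would do remains open. How far compound 1 lies past its value is also unknown: the limit of > 64000 nM in this assay, at which 1 of the 4 values shown sits.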